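The compounds below may be only part of what the source reports. "The series", "measured", "known", "first", "only" and "open" are said of these compounds alone.

Measured in an ADME assay on Huh-7 cells (Homo sapiens) for cytotoxicity; on this read-out higher numbers stand for lower toxicity in this test and lower numbers for higher toxicity in this test:

Compound 1 `NC(=S)N1CCCc2c(OCCCCCOc3cccc4ccccc34)cccc21` — > 50000 nM
Compound 2 `O=C(NC(=S)N1CCc2ccc(OCc3ccccc3)cc21)c1ccccc1` — 43800 nM
Compound 3 `N#Cc1cccc(C(=O)NC(=S)N2CCc3c(OCCCCCOc4ccc(Cl)cc4)cccc32)c1` — 9750 nM

For the measured compounds named here, compound 1 shows a limit of this assay and not a number, the one further value beside the two numbers: the limit of > 50000 nM in this assay, at which 1 of the 3 values shown sits. Compound 2 gives 43800 nM in this assay. Compound 3 gives 9750 nM in this assay, the lowest of the two numbers; compound 2 stands at a higher number, beyond the usual scatter.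

Compound 4 `O=C(NC(=S)N1CCc2c(OCCCCCOc3ccc(Cl)cc3)cccc21)c1ccoc1` has not yet been measured. It differs from compound 3 in one place: furan-3-yl in place of 3-cyanophenyl on a carbonyl carbon. Going by the values given here, no two measured compounds differ in only one place, so no measured step speaks directly to this change. The estimate for compound 4 is a number in the same region as compound 3 or somewhat higher, and the expected step is a 1.5-fold higher number from compound 3 to compound 4 (0.19 log units; within the scatter), likely within or only just beyond the usual scatter. Compound 4 is estimated at 15000 nM in this assay, with a range from 5000 nM to 50000 nM.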

Compound 4, half-maximal cytotoxic concentration: 20100 nM
Compound 4: the middle estimate sits 1.3-fold (0.13 log units) below what was measured; the measured number falls inside the stated range.
By their numbers in this assay, from the lowest: compound 3; then compound 4; then compound 2. At a limit, above all of these: compound 1.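

For the compounds shown here, the first comparison at this position in this assay shows that the group on the carbonyl carbon can move the read-out, though only modestly: a 2.1-fold higher number from compound 3 to compound 4 (0.31 log units; beyond the scatter). With the rest of the molecule unchanged, furan-3-yl, a five-membered aromatic ring with one hetero atom, gives a higher number than 3-cyanophenyl, a six-membered aromatic ring of carbon only that carries the nitrile, so this change goes with lower toxicity in this test, by a margin only just past the usual scatter. Nothing available gives a cause for this step.

The compounds shown leave open whether the step follows the loss of the nitrile or the change of ring. They also leave open how a pyridine ring or a plain alkyl chain on this carbonyl carbon would read.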